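Series notes: smaller saturated ring on the amine side chain

The compounds below may be only part of what the source reports. "The series", "measured", "known", "first", "only" and "open" are said of these compounds alone.

Compound 1 `CCC(C(=O)N[C@@H](CC(=O)O)C(=O)CSCc1ccccc1)n1ccnc(NCC2COc3ccccc3O2)c1=O`, compound 2 `CCC(C(=O)N[C@@H](CC(=O)O)C(=O)CNCN1CCc2ccccc2C1)n1ccnc(NCc2nonc2C)c1=O` and compound 3 `CCC(C(=O)N[C@@H](CC(=O)O)C(=O)CSCc1ccccc1)n1ccnc(NCc2cccs2)c1=O` share one core and are compared in a functional assay on NT2 cells (Homo sapiens) for inhibition; a higher number here means a weaker inhibitor, a lower number a stronger inhibitor. Compound 1 gives 30 nM, compound 3 gives 4.56 nM, and compound 2 gives 1.25 nM. Among the compounds with values here, the single step between neighbours differing in one place is a 6.6-fold lower number from compound 1 to compound 3 (0.82 log units; beyond the scatter), a change on the group attached to the nitrogen on the aromatic ring. Compound 2 stands lowest of the three numbers, with compound 3 its nearest neighbour and compound 1 the furthest, both gaps beyond the scatter.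

Compound 4 `CCC(C(=O)N[C@@H](CC(=O)O)C(=O)CNCN1Cc2ccccc2C1)n1ccnc(NCc2nonc2C)c1=O` is not yet measured. It differs from compound 2 by a group of 9 heavy atoms (8 carbon, 1 nitrogen; one five-membered non-aromatic ring with 1 hetero atom, one six-membered aromatic ring of carbon only) in place of a group of 10 heavy atoms (9 carbon, 1 nitrogen; one six-membered non-aromatic ring with 1 hetero atom, one six-membered aromatic ring of carbon only), on a saturated chain carbon bound to an amine nitrogen. The six-membered non-aromatic ring with 1 hetero atom becomes a five-membered non-aromatic ring with 1 hetero atom; the six-membered aromatic ring of carbon only and the single hydrogen-bond acceptor remain. Within the data shown here, no measured step touches the saturated chain carbon bound to an amine nitrogen; the one known step concerns the other side chain and offers no guide here. The expectation is therefore for a step within the scatter, in no set direction, so compound 4 is expected to give 1.6 nM in this assay, between 0.6 nM and 4.5 nM, an expected step of a 1.3-fold higher number from compound 2 to compound 4 (0.11 log units; within the scatter).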

Compound 4, half-maximal inhibitory concentration: 1.52 nM
Beside the measured number, compound 4's estimate is 1.1-fold (0.02 log units) above it, and the stated range covers the measured number.
By their numbers in this assay, from the lowest: compounds 2 and 4 (each within the scatter of the next); then compound 3; then compound 1.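

Within the data shown here, the first measured step on the saturated chain carbon bound to an amine nitrogen is a 1.2-fold higher number from compound 2 to compound 4 (0.08 log units; within the scatter) in this assay and stays within the scatter. Among these compounds, the earlier compounds gave no reading at this place, since their one step concerned the other side chain; this pair shows that 1,2,3,4-tetrahydroisoquinolin-2-yl and the group with the five-membered non-aromatic ring cannot be told apart here, with the six-membered aromatic ring of carbon only and the single hydrogen-bond acceptor kept in both. Nothing measured on these compounds accounts for the two groups reading alike.

Going by these compounds, both groups keep the aromatic ring, so it remains open whether the number would hold with a simple saturated amine such as piperidine or morpholine, or with an open-chain N-methylbenzylamine, at the same place. Among the compounds shown here, it also remains open whether the benzylsulfanyl group of compound 3 and the amine side chain of compound 2 can be compared directly, since these two compounds differ in more than one place and no step joins them.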